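The source may hold more compounds than are shown below. What is called first, only, known or untested is meant among the compounds shown, and "the series" means these compounds.

The compounds measured in an ADME assay on HEK293 cells (Homo sapiens) for cytotoxicity, with a stated time of 72 h; on this read-out higher numbers stand for an effect only at larger amounts of compound and lower numbers for an effect already at smaller amounts:
Compound 1, `O=C(Nc1cc(-c2nc3ccccc3o2)ccc1F)c1cc([N+](=O)[O-])ccc1Cl`, gives > 25000 nM, a limit of the assay.
Compound 2, `COc1cc(Cl)c(C(=O)Nc2cccc(-c3nc4ccccc4s3)c2)cc1[N+](=O)[O-]`, gives > 25000 nM, a limit of the assay.
Compound 3, `O=C(Nc1cc(-c2nc3ccccc3s2)ccc1F)c1cc([N+](=O)[O-])ccc1Cl`, gives > 25000 nM, a limit of the assay.

Compound 1 stands only at a limit in this assay, and the two further values shown are limits as well, so nothing places it above or below them. Among the measured compounds shown here, the one change between measured compounds that differ in a single place, a step that the two limits leave unreadable from compound 1 to compound 3, stays unreadable between two limits. Compound 4, `COc1ccc(-c2nc3ccccc3o2)cc1NC(=O)c1cc([N+](=O)[O-])ccc1Cl`, differs from compound 1 by methoxy in place of fluoro on an aromatic carbon. For the measured compounds named here, no measured step bears on this change in a readable way: the only step available is unreadable, and every value shown sits at the limit of > 25000 nM in this assay, at which 3 of the 3 values shown sit. Going by the values given here, the account thus has no size of step to carry over and expects, in this assay, nothing readable beyond the scatter, with compound 4 sitting at the limit too. The estimate for compound 4 is 40000 nM, with a range from 25000 nM to 100000 nM, which means an expected step that the limit leaves unreadable from compound 1 to compound 4 that is itself expected to remain unreadable.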

Compound 4, half-maximal effective concentration: > 25000 nM
Compound 4: no number, only a limit; the forecaster's own chance of this, stated with the estimate: 90%; the middle value is on the limit's open side.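

In this assay compound 4 gives > 25000 nM, a limit of the assay. Among the compounds shown here, compound 1 also stands at a limit, so no step between compound 1 and compound 4 can be read. The compounds shown leave open where any of them would reach a half-maximal effect, and whether methoxy in place of fluoro changes that at all.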